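Chloro in Place of Fluoro at the Para Position

This account rests on a few compounds, and the source may have more. Where it says the series, first, only, none or still open, it means among the compounds named here.

Compound 1 `N=C(NCCCc1c[nH]cn1)NCCC(c1ccccc1)c1ccccn1` is the parent of this pair. In a functional assay on muscle tissue for agonist activity at histamine H2 receptor (Cavia porcellus) (a higher number here means a larger maximal response, a lower number a smaller maximal response), compound 1 gives 0.7. Compound 2 `N=C(NCCCc1c[nH]cn1)NCCC(c1ccc(F)cc1)c1ccccn1` carries a fluoro on the same outer ring, and in this assay compound 2 gives 0.8; the step a number 0.10 higher from compound 1 to compound 2 (within the scatter) lies within the scatter, so compound 2 and compound 1 cannot be set apart on these two numbers. Compound 3 `N=C(NCCCc1c[nH]cn1)NCCC(c1ccc(Cl)cc1)c1ccccn1` has not yet been measured. It differs from compound 2 by chloro in place of fluoro on an aromatic carbon. Going by the values given here, the only step that bears on this place is the one from compound 1 to compound 2, where putting a fluoro onto the ring left the response essentially unchanged. A second halogen swap at the same spot is therefore expected to move the number little, in no clear direction. Compound 3 is expected to give 0.8 in this assay, within a range from 0.6 to 1. That estimate means an expected step of no change at the digits printed from compound 2 to compound 3 (within the scatter).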

Compound 3, intrinsic activity: the largest response reached, as a fraction of the reference agonist's: 0.8
The estimate for compound 3 equals the measured number at the digits printed; the measured number falls inside the stated range.
By their numbers in this assay, from the lowest: compounds 1, 2 and 3 (each within the scatter of the next).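

In this assay, the change from 4-fluorophenyl to 4-chlorophenyl gives no change at the digits printed from compound 2 to compound 3 (within the scatter), so at this place on the aromatic ring the two halogens cannot be told apart. The step with chloro in place of hydrogen, a number 0.10 higher from compound 1 to compound 3 (within the scatter), reads the same as the fluoro step, a number 0.10 higher from compound 1 to compound 2 (within the scatter), so neither halogen can be set apart from the hydrogen of the parent, and the earlier pair alone could not show this for a second halogen. No measurement on hand speaks to what lies behind these readings. Going by these compounds, whether a group of another kind at this place, such as an amine, a methoxy group or a carboxylic acid, would shift the maximal response remains open. So does whether a longer chain in the shared core would change the picture.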